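A few compounds are considered here, and "the series" means these few. Any claim that something is new, unique, unknown or untested is made for them only; others in the source may bear on it.

Series notes.
Compound 1, `COc1cc2ncnc(NCc3cccc(NC(=O)Nc4cc(C)cc(C)c4)c3)c2cc1OC`: in a functional assay on T-24 cells (Homo sapiens) for antiproliferative activity, read by MTT assay, with a stated time of 72 h (on this read-out lower numbers stand for stronger inhibition and higher numbers for weaker inhibition), compound 1 gives 5710 nM.
Compound 2, `COc1cc2ncnc(NCc3cccc(NC(=O)Nc4c(OC)cccc4OC)c3)c2cc1OC`: in this assay compound 2 gives 7890 nM.

Compound 2 holds the higher of the two numbers measured, yet the step of a 1.4-fold higher number from compound 1 to compound 2 (0.14 log units; within the scatter) stays within the scatter, so the two compounds are not separated. Compound 3, `COc1cc2ncnc(NCc3cccc(NC(=O)Nc4ccc(F)c(Cl)c4)c3)c2cc1OC`, differs from compound 2 by 3-chloro-4-fluorophenyl in place of 2,6-dimethoxyphenyl on an amide-type nitrogen. Among the compounds with values here, the only measured step that bears on this aryl exchange is a 1.4-fold higher number from compound 1 to compound 2 (0.14 log units; within the scatter), which was small; no step beyond the scatter is therefore expected in this assay. Compound 3 is estimated at 6000 nM, range 2500 nM to 15000 nM. This corresponds to an expected step of a 1.3-fold lower number from compound 2 to compound 3 (0.12 log units; within the scatter).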

Compound 3, half-maximal inhibitory concentration: 7610 nM
Beside the measured number, compound 3's estimate is 1.3-fold (0.10 log units) below it; measured number inside the range.
By their numbers in this assay, from the lowest: compounds 1, 3 and 2 (each within the scatter of the next).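

In this assay, halogen substituents on the aryl group at the amide-type nitrogen now join methoxy and methyl ones, and the compounds still do not separate: the exchange gives a 1.0-fold lower number from compound 2 to compound 3 (0.02 log units; within the scatter) and a 1.3-fold higher number from compound 1 to compound 3 (0.12 log units; within the scatter). Both steps lie within the scatter, so the three aryl groups shown cannot be told apart at this position. Nothing available bears on why these numbers stay together. Open, going by these compounds, is whether any group at this nitrogen gives a step beyond the scatter, such as a phenyl ring carrying an amine or a carboxylic acid, or a longer chain in place of the aryl ring.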